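Shortening the Alkyl Chain on an Inactive Core

The source may report more compounds than this note shows. Statements on the series, on what has been measured and on what is new or still open speak of the compounds shown alone.

Compound 1 `Cc1ccc(C(=O)Nc2nc(Cl)c3cn(CC(C)(C)C)nc3n2)cc1` is known only as a limit in a functional assay on CHO cells for antagonist activity at adenosine receptor A2b (Homo sapiens), read by 33P incorporation, with a stated time of 20 min, in the presence of a further agent that is not named here; a lower number here means a stronger inhibitor, a higher number a weaker inhibitor: compound 1 gives > 10000 nM, which is a limit of the assay rather than a number. Compound 2 `CC(C)(C)Cn1cc2c(Cl)nc(NC(=O)c3ccc(C(F)(F)F)cc3)nc2n1` likewise gives > 20000 nM in this assay, again a limit. The step that the two limits leave unreadable from compound 1 to compound 2 is therefore unreadable, as the two limits the limit of > 10000 nM in this assay, at which 1 of the 2 values shown sits, and the limit of > 20000 nM in this assay, at which 1 of the 2 values shown sits, show. Compound 3 `Cc1ccc(C(=O)Nc2nc(Cl)c3cn(C(C)C)nc3n2)cc1` differs from compound 1 by isopropyl in place of neopentyl on an aromatic nitrogen. Within the data shown here, no measured step bears on this change, so compound 3 is expected to remain at a limit, with an expected step that the limit leaves unreadable from compound 1 to compound 3. Compound 3 is estimated at 15000 nM, within an expected range from 3000 nM to 60000 nM.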

Compound 3, inhibition constant: > 20000 nM
Compound 3: no number, only a limit; the forecaster's own chance of this, stated with the estimate: 80%; at least 1.3-fold (0.12 log units) between middle value and limit.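

Compound 1 and compound 3 both stand only at limits in this assay, and no step can be read between them. The compounds shown leave open whether any change to the shared core gives a measurable inhibition constant.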